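Cytotoxicity notes: from compound 2 to compound 3

The source may hold more compounds than are shown below. What is called first, only, known or untested is meant among the compounds shown, and "the series" means these compounds.

Measured so far:
compound 1, `Cc1ccc2cc(CN(Cc3ccc(C(C)C)cc3)Cc3ccccc3F)c(=O)[nH]c2c1`: > 33000 nM
compound 2, `CCc1ccc2[nH]c(=O)c(CN(Cc3ccc(C(C)(C)C)cc3)Cc3ccc(F)c(F)c3)cc2c1`: > 33000 nM

Both results in a toxicity assay on MDCK cells (Canis lupus familiaris) for cytotoxicity, read by crystal violet staining, with a stated time of 48 h (on this read-out lower numbers stand for higher toxicity in this test and higher numbers for lower toxicity in this test), are limits of the assay rather than numbers. Compound 1 gives > 33000 nM in this assay, which is a limit. Compound 2 gives > 33000 nM in this assay, again a limit. Compound 2 therefore stands at the limit of > 33000 nM in this assay, at which 2 of the 2 values shown sit, and nothing in the shown numbers separates it from compound 1; the two values show only the same limit.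

Compound 3, `CCc1ccc2[nH]c(=O)c(CN(CCCO)Cc3ccc(C(C)(C)C)cc3)cc2c1`, is not yet measured in this assay. It differs from compound 2 by 2-hydroxyethyl in place of 3,4-difluorophenyl on a saturated chain carbon bound to an amine nitrogen; the same difference, cut one bond further out, reads 3,4-difluorobenzyl to 3-hydroxypropyl. Among the compounds with values here, no step between measured compounds exists, so no measured step size guides the expectation. The expected step from compound 2 to compound 3 is a step that the limit leaves unreadable from compound 2 to compound 3, that is, none beyond the scatter, since compound 2 itself sits at a limit. The estimate for compound 3 in this assay is 60000 nM, ranging from 20000 nM to 200000 nM, and most likely reported again as a limit.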

Compound 3, half-maximal cytotoxic concentration: > 10000 nM
Compound 3 was reported as a limit; the forecaster's own chance of this, stated with the estimate: 80%; the middle value is on the limit's open side.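

Within the data shown here, compound 2 and compound 3 are both reported only as limits, so no step between them can be read. The compounds shown leave open where the half-maximal cytotoxic concentration of either one actually lies, and whether 3-hydroxypropyl in place of 3,4-difluorobenzyl changes it at all.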